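From Compound 1 to Compound 3: A Short Chain Added

A few compounds are considered here, and "the series" means these few. Any claim that something is new, unique, unknown or untested is made for them only; others in the source may bear on it.

Going by the values given here, compound 1, with the structure `Cn1nc(-c2cccnc2)c2ccccc2c1=O`, is one of two compounds measured in a functional assay (trachea) with Cavia porcellus as the target; on this read-out higher numbers stand for weaker inhibition and lower numbers for stronger inhibition. In this assay compound 1 gives 11500 nM, the highest of the two numbers. Compound 2, `O=c1c2ccccc2c(-c2cccnc2)nn1CCCCSc1ncccn1`, gives 6170 nM in this assay; the gap between compound 1 and compound 2 lies within the scatter, so the two values show no difference of order. Compound 3, `O=c1c2ccccc2c(-c2cccnc2)nn1CCO`, is not yet measured. It differs from compound 1 by hydroxymethyl in place of hydrogen on a saturated chain carbon bound to an aromatic nitrogen. Among the compounds with values here, no measured pair shows the effect of such a change. Compound 2 carries a longer chain, and its value 6170 nM stays within the scatter of compound 1, so a small step is expected. For compound 3 the expected step is a 1.4-fold lower number from compound 1 to compound 3 (0.16 log units; within the scatter), a modest move toward stronger inhibition, not clearly beyond the scatter. Compound 3 is therefore estimated at 8000 nM, with a range from 3000 nM to 22000 nM.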

Compound 3, half-maximal inhibitory concentration: 4570 nM
Beside the measured number, compound 3's estimate is 1.8-fold (0.24 log units) above it; measured number inside the range.
By their numbers in this assay, from the lowest: compounds 3, 2 and 1 (each within the scatter of the next, the first and the last beyond it).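

In this assay, replacing methyl with 2-hydroxyethyl on the aromatic nitrogen gives a 2.5-fold lower number from compound 1 to compound 3 (0.40 log units; beyond the scatter) and so provides the first sign, though a modest one, that this position responds to a small change. Hydroxy in place of 2-((pyrimidin-2-yl)sulfanyl)ethyl gives a 1.4-fold lower number from compound 2 to compound 3 (0.13 log units; within the scatter) and so does not separate the short chain of compound 3 from the longer chain of compound 2 in this assay. No measurement at hand explains the step seen with compound 3.

The compounds shown leave open whether the hydroxy or the added chain length carries that step, a question that a plain ethyl chain could address. They also leave open how an amine or a carboxylic acid at the end of the chain would read out.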